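Halogen swap on the aryl ring: chloro to fluoro

A few compounds are considered here, and "the series" means these few. Any claim that something is new, unique, unknown or untested is made for them only; others in the source may bear on it.

The series has three measured compounds in an ADME assay on HepG2 cells (Homo sapiens) for cytotoxicity, read by MTT assay, with a stated time of 48 h; on this read-out lower numbers stand for higher toxicity in this test and higher numbers for lower toxicity in this test. Compound 1 `CC(=O)OC[C@H]1O[C@H](OC[C@@H](Cn2cc(CN(c3nc(-c4ccc(Cl)cc4)no3)C3CCCCC3)nn2)OC(C)=O)C=C[C@@H]1OC(C)=O` gives 46.9 ug/mL. Compound 2 `C#CCN(c1nc(-c2ccc(Cl)cc2)no1)C1CCCCC1` gives 41.3 ug/mL, which is the second highest of the three numbers; its nearest neighbour is compound 3 `CC(=O)OC[C@H]1O[C@H](OC[C@@H](Cn2cc(CN(c3nc(-c4ccc(C)cc4)no3)C3CCCCC3)nn2)OC(C)=O)C=C[C@@H]1OC(C)=O` at 36.8 ug/mL, and compound 1 lies on the other side, both within the scatter of compound 2. Among the measured compounds shown here, the one step between compounds that differ in a single place is a 1.3-fold lower number from compound 1 to compound 3 (0.11 log units; within the scatter), so swapping chloro for methyl on the aromatic ring of the shared core left the read-out unchanged within the scatter.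

The next compound, compound 4 `C#CCN(c1nc(-c2ccc(F)cc2)no1)C1CCCCC1`, differs from compound 2 as follows: fluoro in place of chloro on an aromatic carbon. This is again a change of the single substituent on that aromatic carbon, the same place where the chloro-to-methyl step was made. For the measured compounds named here, that step bears on the present one and was within the scatter; no other measured step touches this position. The expectation is therefore that the step of a 1.0-fold lower number from compound 2 to compound 4 (0.00 log units; within the scatter) stays within the scatter in this assay, with no direction to call. Compound 4 is estimated at 41 ug/mL, with a range from 24 ug/mL to 70 ug/mL, awaiting the measurement.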

Compound 4, half-maximal cytotoxic concentration: 41.1 ug/mL
For compound 4 the middle estimate is 1.0-fold (0.00 log units) below the measured one; the range from low to high includes it.
By their numbers in this assay, from the lowest: compounds 3, 4, 2 and 1 (each within the scatter of the next).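

In this assay, the step of a 1.0-fold lower number from compound 2 to compound 4 (0.00 log units; within the scatter) is a second substituent change at this place on the aromatic ring, and it sits on a different remainder of the molecule from the earlier swap. Together with a 1.3-fold lower number from compound 1 to compound 3 (0.11 log units; within the scatter), it shows that the read-out stays within the scatter for both swaps on this aromatic carbon, one on the larger structure shared by compounds 1 and 3 and one on the smaller structure shared by compounds 2 and 4, so within these four compounds nothing goes against that picture. No measurement on hand accounts for this insensitivity at the position.

As far as these compounds go, the substituents compared so far are only chloro, methyl and fluoro, so it remains open how this assay would read with an amine, a carboxylic acid or a methoxy group on this same carbon. Also open, from the compounds shown here alone, are whether 4-chlorophenyl to 4-fluorophenyl behaves the same way on the larger structure, and whether replacing the cyclohexyl ring with a longer chain would move the number beyond the scatter.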